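From hydroxy to chloro on the shared core

The source may report more compounds than this note shows. Statements on the series, on what has been measured and on what is new or still open speak of the compounds shown alone.

Values in a functional assay on DU-145 cells (Homo sapiens) for cytotoxicity, read by MTT assay, with a stated time of 68 h; on this read-out lower numbers stand for stronger inhibition and higher numbers for weaker inhibition:
- compound 1 `O=C(/C=C/c1cccc(OCc2ccccc2)c1)c1ccc([N+](=O)[O-])cc1` gives 52500 nM
- compound 2 `O=C(/C=C/c1cccc(OCc2ccccc2)c1)c1ccc(Cl)cc1Cl` gives 27300 nM
- compound 3 `O=C(/C=C/c1cccc(OCc2ccccc2)c1)c1ccc(O)cc1` gives 6300 nM

Compound 3 holds the lowest number of the three, beyond the scatter from both others. Compound 4 `O=C(/C=C/c1cccc(OCc2ccccc2)c1)c1ccc(Cl)cc1` has chloro in place of hydroxy on an aromatic carbon. Within the data shown here, two measured steps bear on this change: a 4.3-fold lower number from compound 2 to compound 3 (0.64 log units; beyond the scatter) and an 8.3-fold lower number from compound 1 to compound 3 (0.92 log units; beyond the scatter). Neither is the same change, but compound 2 also carries chloro, as its 2,4-dichlorophenyl group. A move to a higher number in this assay is therefore expected, similar in size to the step from compound 2. The expected step is a 3.2-fold higher number from compound 3 to compound 4 (0.50 log units; beyond the scatter). Compound 4 is estimated at 20000 nM with an expected range from 8000 nM to 50000 nM.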

Compound 4, half-maximal inhibitory concentration: 43400 nM
For compound 4 the middle estimate is 2.2-fold (0.34 log units) below the measured one, within the range that was stated.
By their numbers in this assay, from the lowest: compound 3; then compounds 2, 4 and 1 (each within the scatter of the next).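

In this assay the change from 4-hydroxyphenyl to 4-chlorophenyl alone is enough for a clear step (a 6.9-fold higher number from compound 3 to compound 4 (0.84 log units; beyond the scatter)), so the lead of compound 3 goes with the hydroxy at this place, para to a large group. Without that hydroxy the remaining replacements stay within the scatter: the second chloro adds nothing that can be read (a 1.6-fold higher number from compound 2 to compound 4 (0.20 log units; within the scatter)), and chloro and nitro are not told apart (a 1.2-fold lower number from compound 1 to compound 4 (0.08 log units; within the scatter)). The compounds shown leave open whether an amine or a methoxy group here would keep the number of compound 3. No evidence is given on what lies behind this step.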